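The source may hold more compounds than are shown below. What is called first, only, known or untested is meant among the compounds shown, and "the series" means these compounds.

Measured in a functional assay on A549 cells (Homo sapiens) for antiproliferative activity, read by sulforhodamine B assay, with a stated time of 72 h; on this read-out higher numbers stand for weaker inhibition and lower numbers for stronger inhibition:
compound 1 `COc1c(OC(C)C)cc2occ(-c3csc4ccccc34)c(=O)c2c1OC(C)C`: 8900 nM
compound 2 `CCOc1c(OC)cc2occ(-c3csc4ccccc34)c(=O)c2c1OC`: 4800 nM
compound 3 `O=C(/C=C/c1csc2ccccc12)c1ccccc1O`: 5300 nM

Compound 3 lies within the scatter of both compound 2 and compound 1, so these values give no ranking. Compound 4 `Cc1ccc(O)c(C(=O)/C=C/c2csc3ccccc23)c1` differs from compound 3 by methyl in place of hydrogen on an aromatic carbon, para to a hydroxy group. Going by the values given here, no measured pair isolates a single change, so the data offer no precedent for this one. Among the compounds with values here, the only anchor is compound 3 at 5300 nM. In this assay the expected change is none beyond the scatter, with an estimated step of a 1.2-fold lower number from compound 3 to compound 4 (0.07 log units; within the scatter). For compound 4 the estimated value is 4500 nM, with an expected range of 1800 nM to 11000 nM.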

Compound 4, half-maximal inhibitory concentration: 4800 nM
For compound 4 the middle estimate is 1.1-fold (0.03 log units) below the measured one; the range from low to high includes it.
By their numbers in this assay, from the lowest: compounds 2, 4, 3 and 1 (each within the scatter of the next).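

In this assay methyl in place of hydrogen on an aromatic carbon, para to a hydroxy group, gives a 1.1-fold lower number from compound 3 to compound 4 (0.04 log units; within the scatter) and so moves the number by no more than the scatter. Going by these compounds alone, this is the first step that isolates one change, and it shows that this position accepts a methyl with no readable effect. No measurement at hand offers an explanation for this result. On these data alone, whether an amine or a carboxylic acid at the same position would also leave the number unchanged remains open.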